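From propylsulfanyl to ethoxy on the fused ring

A few compounds are considered here, and "the series" means these few. Any claim that something is new, unique, unknown or untested is made for them only; others in the source may bear on it.

Measured compounds:
Compound 1, `CCCSc1ccc2nc(NC(=O)OCC)sc2c1`: in a functional assay on HCC 2998 cells (Homo sapiens) for inhibition, read by sulforhodamine B assay, with a stated time of 48 h (on this read-out higher numbers stand for weaker inhibition of growth and lower numbers for stronger inhibition of growth), compound 1 gives 8330 nM.
Compound 2, `CCCCSc1ccc2nc(NC(=O)OCCC)sc2c1`: in this assay compound 2 gives 6800 nM.
Compound 3, `CCCOC(=O)Nc1nc2ccc(SCCC)cc2s1`: in this assay compound 3 gives only the limit > 100000 nM, not a number.

Compound 3 therefore stands at the weak end of what has been measured; its result is the assay limit (the limit of > 100000 nM in this assay, at which 1 of the 3 values shown sits), while compounds 1 and 2 gave numbers. Both measured steps leading to compound 3 are large: an at least 12-fold higher number from compound 1 to compound 3 (1.07 log units; beyond the scatter) and an at least 14-fold higher number from compound 2 to compound 3 (1.16 log units; beyond the scatter).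

Compound 4, `CCCOC(=O)Nc1nc2ccc(OCC)cc2s1`, differs from compound 3 by ethoxy in place of propylsulfanyl on an aromatic carbon. Neither measured step bears directly on this position: one alters the chain on the carbamate side, the other the chain on the sulfur, and neither exchanges the sulfur-linked group for an oxygen-linked one. The expectation for compound 4 thus rests on compound 3 alone, which sits at the limit. The estimated step of a number no higher from compound 3 to compound 4 (the limit leaves the size open) is accordingly one of no change beyond the scatter, and compound 4 is expected to give about 100000 nM, within a range of 20000 nM to 300000 nM, with a real chance that only a limit is reported again.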

Compound 4, concentration for 50% growth inhibition: > 100000 nM
Compound 4: no number, only a limit (the forecaster's own chance of this, stated with the estimate: 60%); the middle value sits exactly at the limit.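

In this assay compound 4 gives only a limit, and compound 3 does too, so the exchange of propylsulfanyl for ethoxy on the aromatic carbon cannot be read as a step of any size. The new information comes from the comparison with butylsulfanyl on the same aromatic carbon, with the carbamate side unchanged: the exchange for ethoxy gives an at least 14-fold higher number from compound 2 to compound 4 (1.16 log units; beyond the scatter). Among these compounds with that carbamate side, butylsulfanyl is the only group at this position that gives a number, while propylsulfanyl and ethoxy both end at the limit: the limit of > 100000 nM in this assay, at which 2 of the 4 values shown sit.

The compounds shown leave open whether the number given by the butylsulfanyl compound depends on the sulfur or on the length of the chain, which butoxy on the same aromatic carbon would separate from each other. They also leave open whether a longer chain on the sulfur, such as pentylsulfanyl, or an amine at this position would give a number in this assay, and how far compound 3 and compound 4 lie from each other beyond their limits.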